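Removing a Chloro Group From a Cinnamyl Amide Inhibitor

A few compounds are considered here, and "the series" means these few. Any claim that something is new, unique, unknown or untested is made for them only; others in the source may bear on it.

Measured compounds:
compound 1 `O=C(CCCc1ccccc1)Nc1nc2ccccc2c(=O)s1` gives 186 nM
compound 2 `COc1cccc(/C=C/CC(=O)Nc2nc3ccccc3c(=O)s2)c1` gives 2020 nM
compound 3 `O=C(C/C=C/c1cccc(Cl)c1)Nc1nc2ccccc2c(=O)s1` gives 840 nM

These three compounds share one core and were tested in an assay on mitochondria (strain Sprague-Dawley) for inhibition of Amine oxidase [flavin-containing] B (Rattus norvegicus), read by fluorescence and Amplex Red, with stated times of 30 min and 45 min; a lower number here means a stronger inhibitor, a higher number a weaker inhibitor. Compound 1 gives the lowest number among them, and compound 3 stands second, with compound 2 giving the highest number. Among the measured compounds shown here, only one single-point step has been measured so far: a 2.4-fold lower number from compound 2 to compound 3 (0.38 log units; beyond the scatter).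

Compound 4 `O=C(C/C=C/c1ccccc1)Nc1nc2ccccc2c(=O)s1` differs from compound 3 in one place: hydrogen in place of chloro on an aromatic carbon. For the measured compounds named here, no measured step covers the removal of a substituent from this ring, so the step from compound 3 to compound 4 has no direct precedent. Going by the values given here, the one step available, from compound 2 to compound 3, was modest, which suggests that changes at this ring carbon shift the number only moderately. On that basis the step of a 1.2-fold higher number from compound 3 to compound 4 (0.08 log units; within the scatter) is expected to stay close to the scatter, with no strong direction. Compound 4 is therefore estimated at 1000 nM, within a range from 350 nM to 3000 nM.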

Compound 4, half-maximal inhibitory concentration: 361 nM
Beside the measured number, compound 4's estimate is 2.8-fold (0.44 log units) above it; measured number inside the range.
By their numbers in this assay, from the lowest: compounds 1 and 4 (each within the scatter of the next); then compound 3; then compound 2.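

In this assay the unsubstituted phenyl ring gives the lowest number of this series of three, with a 2.3-fold lower number from compound 3 to compound 4 (0.37 log units; beyond the scatter) for hydrogen in place of chloro and a 5.6-fold lower number from compound 2 to compound 4 (0.75 log units; beyond the scatter) for hydrogen in place of methoxy on the same aromatic carbon. The earlier step could only rank chloro against methoxy; with hydrogen as the reference, each of these two groups at this place is seen to carry a higher number than no group at all. Nothing among the data shown explains why the number moves this way.

From the compounds shown here alone, whether any group at this carbon can bring the number lower than hydrogen does remain open, since a fluoro, a methyl or an amine there would each be a new test. Going by these compounds, it is equally open whether chloro would raise the number at the other carbons of the ring.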